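A few compounds are considered here, and "the series" means these few. Any claim that something is new, unique, unknown or untested is made for them only; others in the source may bear on it.

Compound 1 `Cc1cnc(Nc2ccc(C#N)cc2)nc1OC1CCCCC1`, compound 2 `Cc1cnc(Nc2ccc(C#N)cc2)nc1NC1CCCCC1` and compound 3 `Cc1cc(OC2CCCCC2)nc(Nc2ccc(C#N)cc2)n1` were measured in an ADME assay on MT4 cells (Homo sapiens) for cytotoxicity, read by MTT assay; a higher number here means that more compound is tolerated, a lower number that less compound is tolerated. There compound 1 gives 31200 nM, compound 2 gives 1300 nM and compound 3 gives 320 nM. Between the first two the change is cyclohexylamino in place of cyclohexyloxy on an aromatic carbon, and the step it made was a 24-fold lower number from compound 1 to compound 2 (1.38 log units; beyond the scatter). Compound 1 and compound 3 have the same atoms joined differently; the difference between the two cores is not broken down here. Compound 4 `Cc1cc(NC2CCCCC2)nc(Nc2ccc(C#N)cc2)n1` has not yet been measured in this assay. It differs from compound 3 by cyclohexylamino in place of cyclohexyloxy on an aromatic carbon. Among the compounds with values here, this is the same kind of change as the one from compound 1 to compound 2, but not the same: there the place was ortho to a methyl group, here it is meta to a methyl group. Because compound 3 already gives 320 nM and the earlier step was a 24-fold lower number from compound 1 to compound 2 (1.38 log units; beyond the scatter), a step of similar direction is expected, though the cores differ, so the expected step from compound 3 to compound 4 is a 3.2-fold lower number from compound 3 to compound 4 (0.51 log units; beyond the scatter). Compound 4 is therefore estimated at 100 nM, likely between 20 nM and 500 nM.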

Compound 4, half-maximal cytotoxic concentration: 340 nM
Compound 4: middle estimate off by 3.4-fold (0.53 log units), on the low side, and the stated range covers the measured number.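

In this assay, the effect of putting cyclohexylamino in place of cyclohexyloxy did not carry over from one core to the other, as the two steps set side by side show: the same change on two cores in this assay, a 24-fold lower number (1.38 log units; beyond the scatter) from compound 1 to compound 2 and a 1.1-fold higher number (0.03 log units; within the scatter) from compound 3 to compound 4, 26-fold (1.41 log units) apart, beyond the scatter of two such steps. The step on the second core is a 1.1-fold higher number from compound 3 to compound 4 (0.03 log units; within the scatter), so the large step seen on the core of compound 1 cannot be taken as a fixed value for this change across the series. Within the data shown here, this does not show why the two cores respond differently, and with only one pair on each core, it gives no way to say how the same change would behave on a third core.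

The compounds shown leave open how other groups in this place would behave on either core, such as a simple open-chain amine like dimethylamino or a longer chain like hexyloxy. They also leave open whether a core with no methyl group would follow either of the two steps, or neither.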